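The compounds below may be only part of what the source reports. "The series", "measured", "known", "first", "only" and "open" are said of these compounds alone.

Of the compounds shown here, two built on a shared core have been tested in a functional assay on U-937 cells (Homo sapiens) for cytotoxicity, read by MTT assay, with a stated time of 48 h; on this read-out higher numbers stand for weaker inhibition and lower numbers for stronger inhibition. Compound 1 `Clc1cccc2sc(Nc3nc4ccccc4s3)nc12` gives only a limit in this assay, > 50000 nM. Within the data shown here, compound 2 `CCOc1ccc2nc(Nc3nc4ccc(F)cc4s3)sc2c1` gives 26600 nM in this assay, and so stands as the only compound with a measured number. The other value is a limit (the limit of > 50000 nM in this assay, at which 1 of the 2 values shown sits). Compound 3 `Fc1ccc2nc(Nc3nc4ccc(Cl)cc4s3)sc2c1` has not yet been measured. It differs from compound 2 in one place: chloro in place of ethoxy on an aromatic carbon. Among the measured compounds shown here, no measured pair of compounds shows this change, so its size cannot be read from the numbers at hand. Compound 1, which also carries a chloro, gives only a limit > 50000 nM, which suggests weak inhibition for compound 3 as well. The step expected is a 1.5-fold higher number from compound 2 to compound 3 (0.18 log units; within the scatter), toward weaker inhibition and probably beyond the scatter. Compound 3 is estimated at 40000 nM, within 15000 nM to 100000 nM, with a real chance that this assay reports only a limit.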

Compound 3, half-maximal inhibitory concentration: > 50000 nM
Compound 3: only a limit was reported; the forecaster's own chance of this, stated with the estimate: 40%; middle value at least 1.2-fold (0.09 log units) away from the limit.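

Replacing ethoxy with chloro on this aromatic carbon gives, in this assay, an at least 1.8-fold higher number from compound 2 to compound 3 (0.27 log units; that floor lies within the scatter). Among these compounds, compound 3 gives only a limit, so this is the first reading of the change at this position, but it sets a floor and not a full size. The change brings no sign of stronger inhibition, and compound 2 remains the only compound here with a measured number, while limits make up most of the results: the limit of > 50000 nM in this assay, at which 2 of the 3 values shown sit.

On these data alone, how far the true value of compound 3 lies past its limit cannot be read, so it stays unknown whether the step goes beyond the usual scatter. As far as these compounds go, it also remains open whether another group on this carbon, such as an amine, a methoxy or a longer alkoxy chain, would give a measured number, and how that number would compare with compound 2.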